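Replacing Phenoxy with Methyl(pyridin-3-yl)amino: Solubility Outlook

This account rests on a few compounds, and the source may have more. Where it says the series, first, only, none or still open, it means among the compounds named here.

Compound 1 `Cc1nccn1-c1cnc(NCc2c(F)ccc3c2CCO3)c2cn[nH]c(=O)c12`: 7000 nM
Compound 2 `Fc1ccc2c(c1CNc1ncc(Oc3ccccc3)c3nncn13)CCO2`: 8000 nM
Compound 3 `Cc1ncccc1-c1cnc(NCc2c(F)ccc3c2CCO3)c2n[nH]c(=O)n12`: < 2000 nM

Of the compounds shown here, three have been measured in a physicochemical assay for solubility, read by LC-MS, in phosphate buffer, with a stated time of 24 h, at pH 7.4; on this read-out higher numbers stand for higher solubility and lower numbers for lower solubility. Compound 1 gives 7000 nM in this assay, and compound 2 gives 8000 nM. These two numbers lie within the usual scatter of each other, so no order between compound 1 and compound 2 can be read from them. For compound 3 the result in this assay is a limit, < 2000 nM, and not a number; it sits at the limit of < 2000 nM in this assay, at which 1 of the 3 values shown sits.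

The account follows the step from compound 2 to compound 4 `CN(c1cccnc1)c1cnc(NCc2c(F)ccc3c2CCO3)n2cnnc12`, which has not yet been measured in this assay. The change is methyl(pyridin-3-yl)amino in place of phenoxy on an aromatic carbon. Within the data shown here, no measured pair among the three compounds differs in one place, so there is no measured step from which the size of this change can be read directly.

In this assay compound 4 is expected to give about 12000 nM, with a range from 4000 nM to 35000 nM. The step this estimate means, a 1.5-fold higher number from compound 2 to compound 4 (0.18 log units; within the scatter), is expected to be small, possibly a modest rise, but one that may well fall within the scatter.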

Compound 4, solubility: 47000 nM
Compound 4: the middle estimate sits 3.9-fold (0.59 log units) below what was measured; the measured number lies above the stated range.
By their numbers in this assay, from the lowest: compounds 1 and 2 (each within the scatter of the next); then compound 4. At a limit, below all of these: compound 3.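

In this assay, methyl(pyridin-3-yl)amino in place of phenoxy gives a 5.9-fold higher number from compound 2 to compound 4 (0.77 log units; beyond the scatter). Among the earlier compounds no measured pair differed in one place, so this is the first size that can be put on any change here, and it shows that the group on this aromatic carbon can move the number beyond the scatter while the rest of the structure stays the same. The change swaps a ring of carbon only for a ring with 1 hetero atom and also replaces the oxygen link with a nitrogen link bearing a methyl, and nothing measured here bears on why the number rises.

On these data alone, one step cannot separate these two parts of the change, so it remains open whether a pyridin-3-yloxy group or a methyl(phenyl)amino group at this position would carry the same rise, or only part of it. As far as these compounds go, it also remains open whether a smaller group such as a morpholine, or a carboxylic acid on the entering ring, would take the number further in either direction.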